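Adding a Second Chloro to the Sulfonyl Aryl Ring

The compounds below may be only part of what the source reports. "The series", "measured", "known", "first", "only" and "open" are said of these compounds alone.

Compound 2 `CC1=NC(c2cn(S(=O)(=O)c3ccccc3Cl)c3ccc(C)cc23)CN1` holds the lowest of the two numbers measured in an assay on isolated protein for inhibition of kallikrein-7 (Mus musculus), read by fluorescence, with stated times of 10 min and 30 min; a higher number here means a weaker inhibitor, a lower number a stronger inhibitor: compound 2 gives 1500 nM. Its nearest neighbour, compound 3 `CC1=NC(c2cn(S(=O)(=O)c3ccccc3F)c3ccc(C)cc23)CN1`, gives 6400 nM, and the step between them is a 4.3-fold higher number from compound 2 to compound 3 (0.63 log units; beyond the scatter). Compound 1 `CC1=NC(c2cn(S(=O)(=O)c3ccc(Cl)cc3)c3ccc(C)cc23)CN1` reports only a limit in this assay, > 100000 nM. Compound 4 `CC1=NC(c2cn(S(=O)(=O)c3c(Cl)cccc3Cl)c3ccc(C)cc23)CN1` differs from compound 2 by chloro in place of hydrogen on an aromatic carbon, ortho to a large group and meta to a chloro group, so that 2-chlorophenyl becomes 2,6-dichlorophenyl. For the measured compounds named here, no measured step repeats this change. The closest evidence is the step that moves the chloro from 4-chlorophenyl to 2-chlorophenyl, an at least 66-fold lower number from compound 1 to compound 2 (1.82 log units; beyond the scatter), and the exchange of halogens, a 4.3-fold higher number from compound 2 to compound 3 (0.63 log units; beyond the scatter), which shows chloro outdoing fluoro at that site. A second chloro on the ring is therefore expected to keep or slightly lower the number, a step of a 1.7-fold lower number from compound 2 to compound 4 (0.22 log units; within the scatter) in this assay. Compound 4 is estimated at 900 nM, with a range from 250 nM to 4000 nM.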

Compound 4, half-maximal inhibitory concentration: 10000 nM
Compound 4: middle estimate off by 11-fold (1.05 log units), on the low side; measured number outside the range, above it.
By their numbers in this assay, from the lowest: compound 2; then compounds 3 and 4 (each within the scatter of the next). At a limit, above all of these: compound 1.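

In this assay, the second chloro does not extend the gain seen on going from 4-chlorophenyl to 2-chlorophenyl: chloro in place of hydrogen, ortho to a large group and meta to a chloro group, gives a 6.7-fold higher number from compound 2 to compound 4 (0.82 log units; beyond the scatter). The advantage of chloro over fluoro also does not carry over to 2,6-dichlorophenyl, which cannot be told apart from 2-fluorophenyl, with a 1.6-fold higher number from compound 3 to compound 4 (0.19 log units; within the scatter), so 2-chlorophenyl alone stands out among the measured values. Compound 1 holds only a limit, so an at least 10-fold lower number from compound 1 to compound 4 (1.00 log units; beyond the scatter) is a bound rather than a measured size: the limit of > 100000 nM in this assay, at which 1 of the 4 values shown sits.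

The compounds shown leave open how a methyl or methoxy group would fare at this place on the ring. They also leave open whether an amine there would follow the halogens.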